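The compounds below may be only part of what the source reports. "The series", "measured", "known", "first", "only" and "open" are said of these compounds alone.

Measured in a functional assay (blood) for inhibition, with Homo sapiens as the target; on this read-out higher numbers stand for weaker inhibition and lower numbers for stronger inhibition:

- Compound 1 `OC1O[C@H](CO/N=C2\CCc3cc(Sc4cc(F)cc(C5CCOCC5)c4)ccc32)[C@H](O)[C@H](O)[C@H]1O`: > 2500 nM (a limit of the assay, not a number)
- Compound 2 `C/C(=N\OCc1ccncc1)c1ccc(Sc2cc(F)cc(C3CCOCC3)c2)cc1`: 300 nM
- Compound 3 `COC1(c2csc(Sc3ccc4c(c3)CC/C4=N\OCC#N)c2)CCOCC1`: 40 nM

Only two of these entries are true numbers, and compound 2 has the higher one, so it is the weaker inhibitor of that pair. Compound 3 sits lower at 40 nM, and this gap lies beyond the usual scatter of repeated measurements. Compound 1 is reported only as a limit.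

The next molecule, compound 4 `COC(=O)c1cc(CO/N=C(\C)c2ccc(Sc3cc(F)cc(C4CCOCC4)c3)cc2)on1`, is built from compound 2 by one change: 3-(methoxycarbonyl)-1,2-oxazol-5-yl in place of pyridin-4-yl on a saturated chain carbon bound to an oxygen.

Going by the values given here, no measured pair here differs in one place only, so nothing shows directly what such a swap does in this assay. The expectation therefore starts from compound 2 at 300 nM, with a wide margin in either direction. The expected step of a 1.2-fold lower number from compound 2 to compound 4 (0.08 log units; within the scatter) is none beyond the scatter. For compound 4 the estimated value is 250 nM, with an expected range of 70 nM to 1000 nM.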

Compound 4, half-maximal inhibitory concentration: 100 nM
Beside the measured number, compound 4's estimate is 2.5-fold (0.40 log units) above it, and the stated range covers the measured number.
By their numbers in this assay, from the lowest: compound 3; then compound 4; then compound 2. At a limit, above all of these: compound 1.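

Placing 3-(methoxycarbonyl)-1,2-oxazol-5-yl in place of pyridin-4-yl on a saturated chain carbon bound to an oxygen gives a 3.0-fold lower number from compound 2 to compound 4 (0.48 log units; beyond the scatter) in this assay. Going by these compounds alone, this is the first direct reading at this place: a six-membered aromatic ring with one hetero atom is not required there, and a five-membered aromatic ring with two hetero atoms, more heavy atoms and more hydrogen-bond acceptors is accepted, with a modest gain in inhibition. Nothing measured here explains the size of this step.

The ring and its methoxycarbonyl enter together, and the compounds shown do not separate their contributions. A carboxylic acid or a primary amide in place of the methoxycarbonyl, or a plain phenyl ring in place of the new ring, would show which part carries the step.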